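The compounds below may be only part of what the source reports. "The series", "measured", "known", "first", "only" and "open" are said of these compounds alone.

In an ADME assay on microsomes from liver (Rattus norvegicus) for metabolic stability, with a stated time of 60 min, tested at 1 uM (on this read-out higher numbers stand for a more stable compound and lower numbers for a less stable compound), compound 1 `COc1cc(-c2cnn3cc(OC)c(C(C)C)nc23)ccn1` gives 14%. Going by the values given here, it stands lowest of the two compounds measured so far. Compound 2 `Cn1cc(-c2nc3c(-c4ccnc(OC5CC5)c4)cnn3cc2OCC(C)(C)O)cn1` gives 81%, and the gap between the two lies beyond the scatter. Compound 2 differs from compound 1 in more than one place, so this gap does not isolate any single group.

Compound 3 `COc1cc(-c2cnn3cc(OC)c(N(C)C)nc23)ccn1` has not yet been measured. It keeps the core of compound 1 and changes one place: dimethylamino in place of isopropyl on an aromatic carbon. The dimethylamino sits in place of isopropyl on an aromatic carbon, ortho to a methoxy group.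

Among the compounds with values here, no measured pair of compounds shows this exchange, so the expectation starts from compound 1 at 14% and carries wide uncertainty. No step beyond the scatter is expected in this assay, and the estimated change is a number 6 percentage points higher from compound 1 to compound 3 (within the scatter). Compound 3 is expected to give 20%, with an estimated range of 6% to 45%.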

Compound 3, percent of the compound remaining: 3%
Beside the measured number, compound 3's estimate is 17 percentage points above it, outside the stated range (below it).
By their numbers in this assay, from the lowest: compound 3; then compound 1; then compound 2.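

In this assay, going by these compounds alone, the exchange of isopropyl for dimethylamino gives the first direct reading at this place, a number 11 percentage points lower from compound 1 to compound 3 (beyond the scatter), whereas the earlier gap between compound 1 and compound 2 could not be tied to any single group. The result shows that this aromatic carbon, next to the ring nitrogen and ortho to a methoxy group, is sensitive to what it carries: the read-out moves even though the entering and leaving groups have the same count of heavy atoms. Nothing available gives a reason for the step, so the data show only its direction and size.

The compounds shown leave open whether any group at this place, such as a morpholine ring or a tert-butyl group, would leave more compound remaining than isopropyl does in compound 1. They also leave open whether the same exchange would give a similar step with the other groups of compound 2 in place, since that compound differs from compound 1 in more than one place.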